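The compounds below may be only part of what the source reports. "The series", "measured", "known", "first", "only" and "open" are said of these compounds alone.

Measured in a physicochemical assay for lipophilicity, at pH 7.4; on this read-out higher numbers stand for higher lipophilicity and lower numbers for lower lipophilicity:
Compound 1 `COc1cc2c(cc1OC)[C@H](C)C(=O)N(C)C=C2`: 3.4
Compound 2 `COc1ccc2c(c1)C=CN(C)C(=O)[C@@H]2C`: 4.3

Compound 2 has the higher of these two numbers. Compound 1 lies lower by more than the usual scatter of repeated measurements. The next compound, compound 3 `C[C@H]1C(=O)N(C)C=Cc2cc(C(O)CO)ccc21`, has not yet been measured. It differs from compound 2 in one place: 1,2-dihydroxyethyl in place of methoxy on an aromatic carbon. Within the data shown here, no measured pair shows this change, so the size of the step has to be judged rather than read off. Starting from compound 2 at 4.3, a clear fall in this assay is expected, beyond the scatter, given the hydrogen-bond donors that enter. The estimated change is a number 1.70 log units lower from compound 2 to compound 3 (beyond the scatter). For compound 3 the estimated value is 2.6, with an expected range of 1.9 to 3.3.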

Compound 3, distribution coefficient: 1.1
Estimate against measurement, compound 3: 1.50 log units above; measured number below the stated range.
By their numbers in this assay, from the lowest: compound 3; then compound 1; then compound 2.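

Among these compounds, the first measured step at this position is a very large one: replacing methoxy with 1,2-dihydroxyethyl on this aromatic carbon gives a number 3.20 log units lower from compound 2 to compound 3 (beyond the scatter) in this assay. A single change on the core can therefore move this read-out by a wide margin, and compound 3 now marks the low end of the compounds shown. Nothing measured here accounts for the size of this step.

With only this one substitution at this carbon, it remains unclear how much of the step belongs to the length of the chain and how much to its hydroxyl groups. Hydroxymethyl, an amine or a carboxylic acid at the same carbon could begin to separate these contributions and show how the read-out responds to other kinds of group.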